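This account rests on a few compounds, and the source may have more. Where it says the series, first, only, none or still open, it means among the compounds named here.

Measured in a functional assay on A2780 cells (Homo sapiens) for inhibition, read by MTT assay, with a stated time of 72 h; on this read-out lower numbers stand for stronger inhibition and higher numbers for weaker inhibition:
- compound 1 `Cc1cccc(CN2CCc3ncn(COCc4ccccc4)c3/C(=C/c3ccccc3)C2=O)c1` gives 26300 nM
- compound 2 `O=C1/C(=C\c2ccccc2)c2c(ncn2COCc2ccccc2)CCN1Cc1ccc(-c2ccccc2)cc1` gives 48300 nM
- compound 3 `O=C1/C(=C\c2ccccc2)c2c(ncn2COCc2ccccc2)CCN1Cc1ccc(Cl)cc1` gives 22200 nM

Compound 1 stands within the scatter of both other compounds, with a 1.8-fold higher number from compound 1 to compound 2 (0.26 log units; within the scatter) and a 1.2-fold lower number from compound 1 to compound 3 (0.07 log units; within the scatter). Only a 2.2-fold lower number from compound 2 to compound 3 (0.34 log units; beyond the scatter) goes beyond the scatter, and modestly so.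

Compound 4 `Cc1ccccc1CN1CCc2ncn(COCc3ccccc3)c2/C(=C/c2ccccc2)C1=O` has 2-methylphenyl in place of 3-methylphenyl on a saturated chain carbon bound to an amide-type nitrogen in a ring. The two steps from compound 1 replace this same group with others and stay within the scatter, so no step beyond the scatter is expected in this assay here.

For compound 4 the expected value is 28000 nM, with an estimated range from 13000 nM to 55000 nM. The estimate amounts to a 1.1-fold higher number from compound 1 to compound 4 (0.03 log units; within the scatter).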

Compound 4, half-maximal inhibitory concentration: 25300 nM
Beside the measured number, compound 4's estimate is 1.1-fold (0.04 log units) above it, and the stated range covers the measured number.
By their numbers in this assay, from the lowest: compounds 3, 4, 1 and 2 (each within the scatter of the next, the first and the last beyond it).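

In this assay, 2-methylphenyl in place of 3-methylphenyl uses the same atoms joined differently and gives a 1.0-fold lower number from compound 1 to compound 4 (0.02 log units; within the scatter), so where the methyl sits on this ring makes no readable difference here. The other steps at this place, a 1.1-fold higher number from compound 3 to compound 4 (0.06 log units; within the scatter) and a 1.9-fold lower number from compound 2 to compound 4 (0.28 log units; within the scatter), also stay within the scatter. No supporting measurement says why these numbers lie so close.

The compounds shown leave open whether an amine or a carboxylic acid on this aromatic ring would give a step beyond the scatter.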